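A few compounds are considered here, and "the series" means these few. Any claim that something is new, unique, unknown or untested is made for them only; others in the source may bear on it.

Measured compounds:
Compound 1, `N#CC1=C(N)Oc2c(c3nc4ccccc4nc3c3ccccc23)C12C(=O)N(Cc1cnnn1-c1ccc([N+](=O)[O-])cc1)c1ccccc12`: in a functional assay on A549 cells (Homo sapiens) for antiproliferative activity, read by MTT assay, with a stated time of 48 h (on this read-out higher numbers stand for weaker inhibition and lower numbers for stronger inhibition), compound 1 gives > 50000 nM, a limit of the assay.
Compound 2, `Cc1ccc(-n2nncc2CN2C(=O)C3(C(C#N)=C(N)Oc4c3c3nc5ccccc5nc3c3ccccc43)c3ccccc32)cc1C`: in this assay compound 2 gives > 50000 nM, also a limit.
Compound 3, `Cc1ccccc1-n1nncc1CN1C(=O)C2(C(C#N)=C(N)Oc3c(N)cc4nc5ccccc5nc4c32)c2ccccc21`: in this assay compound 3 gives 31700 nM.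

Among the measured compounds shown here, compound 3 is the only member of the set with a measured number; the other two values sit at the limit of > 50000 nM in this assay, at which 2 of the 3 values shown sit. For the measured compounds named here, the only step between measured compounds that differ in one place is a step that the two limits leave unreadable from compound 1 to compound 2, and both its ends are limits, so its size cannot be read.

Compound 4, `COc1ccc(OC)c(-n2nncc2CN2C(=O)C3(C(C#N)=C(N)Oc4c(N)cc5nc6ccccc6nc5c43)c3ccccc32)c1`, differs from compound 3 by 2,5-dimethoxyphenyl in place of 2-methylphenyl on an aromatic nitrogen. Going by the values given here, no measured step in this assay with a readable size covers an exchange at this aromatic nitrogen, so the expectation rests on compound 3 alone. With nothing to suggest movement in either direction, the step from compound 3 to compound 4 is expected to stay within the scatter of repeated measurements, a 1.0-fold higher number from compound 3 to compound 4 (0.02 log units; within the scatter). Compound 4 is therefore estimated at 33000 nM in this assay, with a range from 12000 nM to 60000 nM, and a fair chance that only a limit is reported.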

Compound 4, half-maximal inhibitory concentration: 28100 nM
Compound 4: the middle estimate sits 1.2-fold (0.07 log units) above what was measured; low and high end bracket the measured number.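

At this aromatic nitrogen, an exchange now has a readable size in this assay: a 1.1-fold lower number from compound 3 to compound 4 (0.05 log units; within the scatter). On the core of compound 3, the entering 2,5-dimethoxyphenyl carries 10 heavy atoms and 2 hydrogen-bond acceptors against 7 and 0 for 2-methylphenyl, and the read-out does not separate the two compounds. The earlier exchange at this nitrogen, from compound 1 to compound 2, cannot be read since both its ends are limits: the limit of > 50000 nM in this assay, at which 2 of the 4 values shown sit.

Open, from the compounds shown here alone, is whether a carboxylic acid or a dimethylamino group on this phenyl ring, or a longer alkyl chain in its place, would move the number beyond the scatter on the core of compound 3. Also open, going by these compounds, is whether the flat step seen here carries over to the core of compound 1.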